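Removing the aryl methyl from a fluorinated cyclopentane acid

This account rests on a few compounds, and the source may have more. Where it says the series, first, only, none or still open, it means among the compounds named here.

Compound 1 `Cc1ccc(S(=O)(=O)N[C@H]2CC[C@@H](F)[C@@H]2C/C=C\CCCC(=O)O)cc1` is the reference point of this small set. In a functional assay on a cell-free system (plasma) for inhibition of thromboxane A2 receptor (Homo sapiens), read by turbidimetry (on this read-out lower numbers stand for stronger inhibition and higher numbers for weaker inhibition), compound 1 gives 260 nM. Compound 2 `O=C(O)CCC/C=C\C[C@H]1[C@H](F)CC[C@@H]1NS(=O)(=O)c1ccccc1` differs from it only by hydrogen in place of methyl on an aromatic carbon. In this assay compound 2 gives 1100 nM, so the step is a 4.2-fold higher number from compound 1 to compound 2 (0.63 log units; beyond the scatter). Compound 3 `Cc1ccc(S(=O)(=O)N[C@H]2CC[C@@H](F)[C@@H]2CCCCOCC(=O)O)cc1` keeps the same sulfonamide and fluorinated ring as compound 1 but carries another acid-bearing chain: 3-(carboxymethoxy)propyl in place of 5-carboxypent-1-en-1-yl on a saturated chain carbon bound to a saturated ring carbon. In this assay compound 3 gives 1800 nM, a step of a 6.9-fold higher number from compound 1 to compound 3 (0.84 log units; beyond the scatter).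

Compound 4 `O=C(O)COCCCC[C@H]1[C@H](F)CC[C@@H]1NS(=O)(=O)c1ccccc1` has not yet been measured. It differs from compound 3 by hydrogen in place of methyl on an aromatic carbon, which is the same change as that between compound 1 and compound 2, at a place described in the same words. Among the measured compounds shown here, the only guide in this assay for that change is therefore a 4.2-fold higher number from compound 1 to compound 2 (0.63 log units; beyond the scatter), made on the other chain. The step from compound 3 to compound 4 is expected to be about as large, a 4.2-fold higher number from compound 3 to compound 4 (0.62 log units; beyond the scatter), although the differing chain leaves room for it to fall short or overshoot. Compound 4 is thus estimated to give 7500 nM in this assay, most likely between 2500 nM and 25000 nM.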

Compound 4, half-maximal inhibitory concentration: 1700 nM
Compound 4: the middle estimate sits 4.4-fold (0.64 log units) above what was measured; measured number outside the range, below it.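

Removing the methyl does not carry over from one chain to the other. In this assay, the change from 4-methylphenyl to phenyl gives a 1.1-fold lower number from compound 3 to compound 4 (0.02 log units; within the scatter), so on the 3-(carboxymethoxy)propyl chain it leaves no readable effect, and this differs from the step on the 5-carboxypent-1-en-1-yl chain: the same change on two cores in this assay, a 4.2-fold higher number (0.63 log units; beyond the scatter) from compound 1 to compound 2 and a 1.1-fold lower number (0.02 log units; within the scatter) from compound 3 to compound 4, 4.5-fold (0.65 log units) apart, beyond the scatter of two such steps. Seen from the other side, the swap of chains also depends on the aryl group, since among the phenyl compounds it gives a 1.5-fold higher number from compound 2 to compound 4 (0.19 log units; within the scatter), which differs from the step among the 4-methylphenyl compounds: the same change on two cores in this assay, a 6.9-fold higher number (0.84 log units; beyond the scatter) from compound 1 to compound 3 and a 1.5-fold higher number (0.19 log units; within the scatter) from compound 2 to compound 4, 4.5-fold (0.65 log units) apart, beyond the scatter of two such steps. These four compounds show that the two changes do not simply add up in this set, but they cannot show why, or whether the same holds elsewhere in the series.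

Going by these compounds, it remains open whether a chlorine atom or a methoxy group in place of the methyl would matter on one chain only, as the methyl does here. A longer acid-bearing chain is equally untested by the compounds shown.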